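The source may hold more compounds than are shown below. What is called first, only, known or untested is meant among the compounds shown, and "the series" means these compounds.

Working notes on the series. The shared core carries a sulfonyl-linked piperazine bearing an aryl group at its far nitrogen. Compound 1 `O=C1Cc2cc(S(=O)(=O)N3CCN(c4ccc(O)cc4)CC3)ccc2N1` has a hydroxy on that aryl ring, and in an assay on isolated protein for inhibition of lysosomal alpha-glucosidase (Homo sapiens), read by fluorescence, with stated times of 5 min and 45 min (a lower number here means a stronger inhibitor, a higher number a weaker inhibitor), compound 1 gives 1880 nM. Compound 2 `N#Cc1ccc(N2CCN(S(=O)(=O)c3ccc4c(c3)CC(=O)N4)CC2)cc1` carries a cyano there instead; in this assay compound 2 gives 2910 nM. The step of a 1.5-fold higher number from compound 1 to compound 2 (0.19 log units; within the scatter) does not separate the two, so the numbers of compound 2 and compound 1 sit within the scatter of each other and no order between them is resolved.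

Compound 3 `O=C1Cc2cc(S(=O)(=O)N3CCN(c4ccc(F)cc4)CC3)ccc2N1` is the next member. Relative to compound 2 the change is fluoro in place of cyano on an aromatic carbon. Within the data shown here, only one measured step touches the same position, the exchange from hydroxy to cyano, and it was a 1.5-fold higher number from compound 1 to compound 2 (0.19 log units; within the scatter), within the scatter. Among the measured compounds shown here, nothing among the measured pairs speaks to fluoro in this place. The step expected from compound 2 to compound 3 is therefore small, a 1.3-fold lower number from compound 2 to compound 3 (0.10 log units; within the scatter), with no direction resolved beyond the scatter. Compound 3 is estimated at 2300 nM in this assay, with a range of 900 nM to 6000 nM.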

Compound 3, half-maximal inhibitory concentration: "not active" (no number reported)
For compound 3 the study gives words and no number, and the estimate cannot be compared.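

In this assay, among these compounds, compound 3 is reported only as "not active", without a number, so no step from compound 2 or compound 1 to compound 3 can be read. Nothing in the data shown bears on this result. The compounds shown leave open how fluoro compares with cyano or hydroxy at this place in numerical terms.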